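The source may hold more compounds than are shown below. What is called first, only, known or untested is meant among the compounds shown, and "the series" means these compounds.

Within the data shown here, compound 2 `CCO[C@]1(c2ccc(OCc3c(-c4c(Cl)cccc4Cl)noc3C3CC3)cc2Cl)C[C@H](c2cccc(C(=O)O)c2)C1` gives 277 nM in an assay on isolated protein for agonist activity at Bile acid receptor (Homo sapiens), read by FRET (a higher number here means that more compound is needed for the effect, a lower number that less compound is needed), the highest of the three numbers measured so far. Compound 1 `O=C(O)c1cccc([C@H]2C[C@@H](c3ccc(OCc4c(-c5c(Cl)cccc5Cl)noc4C4CC4)cc3Cl)C2)c1` gives 77 nM and compound 3 `CC(C)n1nc(C(=O)O)cc1C1CC1c1ccc(OCc2c(-c3c(Cl)cccc3Cl)noc2C2CC2)cc1Cl` gives 7 nM in this assay. The change under consideration is hydroxy in place of hydrogen on a saturated chain carbon, two bonds along the chain from an oxygen on a saturated carbon, which gives compound 4 `O=C(O)c1cccc([C@H]2C[C@](OCCO)(c3ccc(OCc4c(-c5c(Cl)cccc5Cl)noc4C4CC4)cc3Cl)C2)c1`. Among the measured compounds shown here, the only measured step that touches this part of the molecule is a 3.6-fold higher number from compound 1 to compound 2 (0.56 log units; beyond the scatter), a modest shift; no measured pair shows a hydroxy added to such a chain, so the hydroxy itself has no precedent here. For the measured compounds named here, with that modest step as the only guide, the expected step in this assay is a 1.1-fold lower number from compound 2 to compound 4 (0.04 log units; within the scatter), within the scatter in either direction. Compound 4 is therefore estimated at 250 nM, with a range of 90 nM to 700 nM.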

Compound 4, half-maximal effective concentration: 373 nM
Compound 4: the middle estimate sits 1.5-fold (0.17 log units) below what was measured; the range from low to high includes it.
By their numbers in this assay, from the lowest: compound 3; then compound 1; then compounds 2 and 4 (each within the scatter of the next).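

In this assay, hydroxy on the saturated chain carbon gives a 1.3-fold higher number from compound 2 to compound 4 (0.13 log units; within the scatter), so ethoxy and 2-hydroxyethoxy cannot be told apart at this position. Measured against hydrogen on the saturated ring carbon, 2-hydroxyethoxy gives a 4.8-fold higher number from compound 1 to compound 4 (0.69 log units; beyond the scatter), so the gap to hydrogen remains beyond the scatter with the hydroxy in place.

Going by these compounds, whether an amine or a carboxylic acid in place of this hydroxy, or a longer chain, would move the number away from that of compound 2 stays open. No available evidence bears on the reason for either step.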